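Fluorine shift on the ring-nitrogen aryl: compound 4

The source may hold more compounds than are shown below. What is called first, only, known or untested is meant among the compounds shown, and "the series" means these compounds.

Three compounds of this series have been run in a functional assay on HOS-TE85 cells (Homo sapiens) for inhibition, read by CCK-8 assay, with a stated time of 72 h, tested at 1 uM; on this read-out lower numbers stand for less inhibition and higher numbers for more inhibition at the one concentration tested (going by the name of the read-out). Compound 1 `COc1ccc(C)cc1N1C(=O)CSC1c1cccc(C(=O)NCCCCc2ccccc2)c1` gives 95%. Compound 2 `COc1cc(F)ccc1N1C(=O)CSC1c1cccc(C(=O)NCCCCc2ccccc2)c1` gives 94%. Compound 3 `O=C(NCCCCc1ccccc1)c1cccc(C2OCC(=O)N2c2cccc(F)c2)c1`, which carries a different five-membered ring and a different aryl on the ring nitrogen, gives 87%. On these numbers compound 2 sits inside the range spanned by compound 1 and compound 3, and both gaps are within the usual scatter, so no ordering among the three can be read off.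

The next compound, compound 4 `COc1c(F)cccc1N1C(=O)CSC1c1cccc(C(=O)NCCCCc2ccccc2)c1`, differs from compound 2 only in the aryl on the ring nitrogen: 3-fluoro-2-methoxyphenyl in place of 4-fluoro-2-methoxyphenyl on an amide-type nitrogen in a ring.

Going by the values given here, the one measured step that touches this position is the swap of the aryl on that nitrogen from compound 1 to compound 2, which gave a number 1 percentage points lower from compound 1 to compound 2 (within the scatter). Among the compounds with values here, compound 3 shares no single-point step with compound 2, so its value only shows that a different aryl on a different ring still sits close. Moving the fluorine within the same ring is a smaller change than either of those, so the step from compound 2 to compound 4 is expected to be a number 2 percentage points lower from compound 2 to compound 4 (within the scatter), that is, nothing beyond the scatter.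

Compound 4 is therefore estimated at 92% in this assay, with a range of 82% to 98%.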

Compound 4, a percentage reported as inhibition, at one concentration (the size of the read-out at that concentration, not a potency): 12%
Compound 4: the middle estimate sits 80 percentage points above what was measured; measured number below the stated range.
By their numbers in this assay, from the lowest: compound 4; then compounds 3, 2 and 1 (each within the scatter of the next).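

In this assay, the aryl on the amide-type nitrogen had looked undemanding, with only a number 1 percentage points lower from compound 1 to compound 2 (within the scatter). The new result changes that picture: a number 82 percentage points lower from compound 2 to compound 4 (beyond the scatter), although 3-fluoro-2-methoxyphenyl and 4-fluoro-2-methoxyphenyl have the same atoms and the same counts, so this read-out depends on where the fluorine stands on this ring and not merely on which atoms the aryl carries. The 3-fluoro-2-methoxyphenyl group also separates from the methyl-bearing aryl of compound 1, with a number 83 percentage points lower from compound 1 to compound 4 (beyond the scatter), while no data at hand explain the loss.

Going by these compounds, it remains open whether the loss belongs to fluorine itself at this place or to any substituent there, which a chlorine or a methyl group in place of the fluorine of compound 4, or an aryl carrying only the methoxy group, would help to separate. On these data alone, with a single concentration behind each number, it also remains open how far the potency of compound 4 lies from that of compound 2, and whether the same fluorine shift has a comparable effect on the other five-membered ring seen in compound 3.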